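The source may hold more compounds than are shown below. What is called first, only, known or untested is meant among the compounds shown, and "the series" means these compounds.

Measured compounds:
compound 1 `N#Cc1ccc(-c2nc(N)c3cc(Cc4ccccc4)sc3n2)o1` — 3160 nM
compound 2 `Cc1nc(-c2nc(N)c3cc(Cc4ccccc4)sc3n2)cs1` — 263 nM
compound 3 `Nc1nc(-c2ccccn2)nc2sc(Cc3ccccc3)cc12` — 3710 nM

In a functional assay on CHO-K1 cells for antagonist activity at adenosine receptor A1 (Homo sapiens), read by a beta-galactosidase reporter and cAMP accumulation, with stated times of 15 min and 6 h (on this read-out lower numbers stand for stronger inhibition and higher numbers for weaker inhibition), compound 3 gives the highest of the three numbers. Against compound 1 the difference is a 1.2-fold higher number from compound 1 to compound 3 (0.07 log units; within the scatter), so those two are not separated; against compound 2 it is a 14-fold higher number from compound 2 to compound 3 (1.15 log units; beyond the scatter), a large gap.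

Compound 4 `Nc1nc(-c2cccnc2)nc2sc(Cc3ccccc3)cc12` is not yet measured. It differs from compound 3 by pyridin-3-yl in place of pyridin-2-yl on an aromatic carbon.

Among the compounds with values here, no measured step changes one pyridyl for another. Within the data shown here, the steps that bear on this position swap one heteroaryl group for a different one: a 12-fold lower number from compound 1 to compound 2 (1.08 log units; beyond the scatter) and a 14-fold higher number from compound 2 to compound 3 (1.15 log units; beyond the scatter) are large, while a 1.2-fold higher number from compound 1 to compound 3 (0.07 log units; within the scatter) is within the scatter. The position therefore tolerates both large and negligible changes, and nothing in the three compounds fixes the direction for a pyridin-3-yl group. The step of a 1.2-fold lower number from compound 3 to compound 4 (0.09 log units; within the scatter) is expected to be small, with a wide range either way. Compound 4 is estimated at 3000 nM (range 600 nM to 15000 nM) in this assay.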

Compound 4, inhibition constant: 1420 nM
Compound 4: the middle estimate sits 2.1-fold (0.32 log units) above what was measured, and the stated range covers the measured number.
By their numbers in this assay, from the lowest: compound 2; then compound 4; then compounds 1 and 3 (each within the scatter of the next).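

In this assay, pyridin-3-yl in place of pyridin-2-yl gives a 2.6-fold lower number from compound 3 to compound 4 (0.42 log units; beyond the scatter), so this position responds to a change between two groups with the same atoms, joined differently, and not only to a change of heteroaryl type. The pyridin-3-yl group also separates from the 5-cyanofuran-2-yl group, with a 2.2-fold lower number from compound 1 to compound 4 (0.35 log units; beyond the scatter), but does not reach the 2-methyl-1,3-thiazol-4-yl group, with a 5.4-fold higher number from compound 2 to compound 4 (0.73 log units; beyond the scatter), so compound 4 stands in the middle and compound 2 keeps the lowest number. No measured data explain these differences.

Open, from the compounds shown here alone, is whether pyridin-4-yl or plain phenyl at this place would fall nearer compound 2 or compound 3. Also open, going by these compounds, is whether a methyl group on the pyridin-3-yl ring would narrow the remaining gap to compound 2.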